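Silyl-protected cyclopentenone: swapping one aryl ring

The compounds below may be only part of what the source reports. "The series", "measured", "known", "first", "only" and "open" are said of these compounds alone.

Compound 1, `COc1ccc(C2=C(c3cc(OC)c(OC)c(OC)c3)C(=O)CC2O)cc1O`: < 1 ug/mL
Compound 2, `COc1cc(C2=C(c3cc(C)c(OC)c(C)c3)C(O[SiH2]C(C)(C)C)CC2=O)cc(OC)c1OC`: > 100 ug/mL

Both known values are limits of the assay rather than numbers. In an ADME assay on L132 cells (Homo sapiens) for cytotoxicity, read by MTT assay, with a stated time of 72 h (a lower number here means a stronger inhibitor, a higher number a weaker inhibitor), compound 1 gives < 1 ug/mL, a limit. In the same assay compound 2 gives > 100 ug/mL, also a limit, as noted in the limit of > 100 ug/mL in this assay, at which 1 of the 2 values shown sits; it therefore stands at the weak end of the two values shown, while compound 1 sits at the other limit described in the limit of < 1 ug/mL in this assay, at which 1 of the 2 values shown sits.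

Compound 3, `COc1ccc(C2=C(c3cc(OC)c(OC)c(OC)c3)C(=O)CC2O[SiH2]C(C)(C)C)cc1O`, is not yet measured. It differs from compound 2 by 3-hydroxy-4-methoxyphenyl in place of 4-methoxy-3,5-dimethylphenyl on a double-bonded ring carbon. Going by the values given here, since no measured step covers this kind of change, the size expected for it rests on the two limits alone. The expectation is that compound 3 gives 20 ug/mL, between 3 ug/mL and 100 ug/mL, so that the estimated step of an at least 5.0-fold lower number from compound 2 to compound 3 (0.69 log units; beyond the scatter) points toward a stronger effect, beyond the usual scatter.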

Compound 3, half-maximal inhibitory concentration: < 1 ug/mL
Compound 3: only a limit was reported (the forecaster's own chance of this, stated with the estimate: 30%); middle value at least 20-fold (1.30 log units) from the limit.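

With the silyl-bearing oxygen left unchanged, placing 3-hydroxy-4-methoxyphenyl in place of 4-methoxy-3,5-dimethylphenyl on a double-bonded ring carbon gives an at least 100-fold lower number from compound 2 to compound 3 (2.00 log units; beyond the scatter) in this assay. Going by these compounds alone, this is the first readable step, and it shows that a change to this one aryl ring alone can carry a compound from one end of the reported range to the other. Compound 3 also shows that the silyl group and a strong result can occur together in one molecule, as its value of < 1 ug/mL is a limit at the strong end.

As far as these compounds go, the step from compound 1 to compound 3 cannot be read, so the effect of the silyl group itself remains open. The swap also removes two methyl groups and adds a hydroxyl at once, so it remains unclear which part matters, and whether an amine in place of that hydroxyl would give a similar result.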